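The compounds below may be only part of what the source reports. "The series", "measured", "known", "first", "only" and "open" are said of these compounds alone.

Measured in an assay on isolated protein for inhibition of protein kinase C zeta type (Homo sapiens), with stated times of 1 h and 2.5 min, tested at 30 uM; on this read-out higher numbers stand for more inhibition at the one concentration tested (going by the name of the read-out) and lower numbers for less inhibition:
compound 3, `CCOC(=O)c1c(-c2cccc(C)c2)csc1N`, gives 77%;
compound 2, `COc1ccc(-c2csc(N)c2C(=O)O)cc1OC`, gives 65%;
compound 1, `COc1ccc(-c2csc(N)c2C(=O)NCc2ccccc2)cc1OC`, gives 43%.

Compound 3 stands highest of the three numbers; compound 2 comes nearest and compound 1 furthest, both beyond the usual scatter. Within the data shown here, the only step among measured pairs, a number 22 percentage points higher from compound 1 to compound 2 (beyond the scatter), concerns a group on a carbonyl carbon, so it says nothing about changes on the aromatic ring. Compound 4, `CCOC(=O)c1c(-c2cccc(C(F)(F)F)c2)csc1N`, differs from compound 3 by trifluoromethyl in place of methyl on an aromatic carbon. Among the measured compounds shown here, with no measured step bearing on this change, the step of a number 5 percentage points lower from compound 3 to compound 4 (within the scatter) is expected to stay within the scatter. Compound 4 is therefore estimated at 72%, with a range from 50% to 90%.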

Compound 4, a percentage reported as inhibition, at one concentration (the size of the read-out at that concentration, not a potency): 30%
Estimate against measurement, compound 4: 42 percentage points above; the whole stated range lies above it.
By their numbers in this assay, from the lowest: compound 4; then compound 1; then compound 2; then compound 3.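

Swapping methyl for trifluoromethyl on this aromatic carbon, meta to a large group, gives a number 47 percentage points lower from compound 3 to compound 4 (beyond the scatter) and so shows that this position is sensitive to what sits on it. Among these compounds, the only earlier step concerned a group on a carbonyl carbon, so this is the first sign that a change on the aromatic ring can move the number. No measurement shown explains the drop.

Going by these compounds, whether a chlorine, an ethyl group or an amine at this place would stay close to compound 3 remains open. So does whether the same swap would have a similar effect with a carboxylic acid on the carbonyl carbon.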